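Enaminone series on breast-cancer cells: indole for dimethoxyphenyl

The source may report more compounds than this note shows. Statements on the series, on what has been measured and on what is new or still open speak of the compounds shown alone.

Compound 1 `COc1ccc(N/C=C\C(=O)c2nc(-c3ccc(C(F)(F)F)cc3)n3ccccc23)cc1OC` was tested in a functional assay on MDA-MB-231 cells (Homo sapiens) for cytotoxicity, read by MTT assay, with a stated time of 48 h; on this read-out higher numbers stand for weaker inhibition and lower numbers for stronger inhibition; for compound 1 the result is only a limit, > 30000 nM. Compound 2 `COc1ccc(-c2nc(C(=O)/C=C\Nc3ccc(Cl)cc3)c3ccccn23)cc1` likewise returns only a limit in this assay, > 30000 nM. Everything shown amounts to the limit of > 30000 nM in this assay, at which 2 of the 2 values shown sit, so compound 1 stands at the weak end of the series and no step between measured compounds exists to guide. Compound 3 `O=C(/C=C\Nc1ccc2[nH]ccc2c1)c1nc(-c2ccc(C(F)(F)F)cc2)n2ccccc12` carries 1H-indol-5-yl in place of 3,4-dimethoxyphenyl on an amine nitrogen. In this assay the expected step is an at least 1.2-fold lower number from compound 1 to compound 3 (0.07 log units; that floor lies within the scatter), none beyond the scatter. Compound 3 is estimated at 25000 nM, with a range from 5000 nM to 100000 nM.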

Compound 3, half-maximal inhibitory concentration: 1180 nM
Estimate against measurement, compound 3: 21-fold (1.33 log units) above; measured number below the stated range.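

In this assay, the group on the amine nitrogen can move the read-out: replacing 3,4-dimethoxyphenyl with 1H-indol-5-yl gives an at least 25-fold lower number from compound 1 to compound 3 (1.40 log units; beyond the scatter). That step is a floor, since its starting point is a limit. Compound 3 is the only compound shown with a number rather than a limit: the limit of > 30000 nM in this assay, at which 2 of the 3 values shown sit.

On these data alone, whether the step depends on the hydrogen-bond donor of 1H-indol-5-yl or on its five-membered ring remains open; a methyl group on the indole nitrogen would separate the two. Also open, as far as these compounds go, is whether 1H-indol-5-yl has the same effect with a group other than 4-(trifluoromethyl)phenyl on the core.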